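Diethylamino for pyrrolidin-1-yl at the assay limit

The source may report more compounds than this note shows. Statements on the series, on what has been measured and on what is new or still open speak of the compounds shown alone.

Compound 1 `CC(=O)c1ccc(-c2ccc(N3CCCC3)nn2)cc1` reads > 25000 nM in an ADME assay on cells (Fibroblast, Homo sapiens) for antiproliferative activity, with a stated time of 48 h (a lower number here means a stronger inhibitor, a higher number a weaker inhibitor), as a limit of the assay and not a number. Compound 2 `COC(=O)c1cccc(-c2ccc(-n3cccc3)nn2)c1` reads > 25000 nM in this assay, also a limit. Compound 3 `CCN(CC)c1ccc(-c2cccc(C#N)c2)nn1` reads > 25000 nM in this assay, again a limit, and it carries diethylamino. Compound 1 therefore stands at the limit of > 25000 nM in this assay, at which 3 of the 3 values shown sit, and holds no rank of its own. Within the data shown here, no measured pair differs in one place, so the series offers no step from which to size a change.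

Compound 4 `CCN(CC)c1ccc(-c2ccc(C(C)=O)cc2)nn1` is compound 1 with diethylamino in place of pyrrolidin-1-yl on an aromatic carbon. No step beyond the scatter is expected in this assay, and a reading at the limit is the likeliest outcome, as compound 3 with the same diethylamino gives > 25000 nM. The estimated step is a number no higher from compound 1 to compound 4 (the limit leaves the size open) and is expected to be nominal only. For compound 4 the estimated value is 25000 nM (expected range 12000 nM to 50000 nM).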

Compound 4, half-maximal inhibitory concentration: > 25000 nM
Compound 4 ended at the assay's limit; the forecaster's own chance of this, stated with the estimate: 75%; the middle value sits exactly at the limit.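

No step can be read from compound 1 to compound 4, since both readings are limits and not numbers: the limit of > 25000 nM in this assay, at which 4 of the 4 values shown sit.

The compounds shown leave open which change to the shared core, if any, gives a number rather than a limit in this assay.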